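Trifluoromethyl on the Benzylsulfanyl Ring of Compound 1

This account rests on a few compounds, and the source may have more. Where it says the series, first, only, none or still open, it means among the compounds named here.

Compound 1 `Cc1cc(S(=O)(=O)/N=C(\N)N/N=C/C#Cc2ccccc2)c(SCc2ccccc2)cc1Cl` gives the lowest number among the three measured compounds in a functional assay on HCT-116 cells (Homo sapiens) for antiproliferative activity, read by MTT assay, with a stated time of 72 h (a higher number here means a weaker inhibitor, a lower number a stronger inhibitor), at 8000 nM. Compound 2 `C/C(C#Cc1ccccc1)=N\N/C(N)=N/S(=O)(=O)c1cc(C)c(Cl)cc1SCc1ccccc1` gives 10000 nM in this assay, and a 1.3-fold higher number from compound 1 to compound 2 (0.10 log units; within the scatter). Compound 3 `C/C(C#Cc1ccccc1)=N\N/C(N)=N/S(=O)(=O)c1cc(C)c(Cl)cc1SCc1ccccc1C(F)(F)F` gives 23000 nM, so that a 2.3-fold higher number from compound 2 to compound 3 (0.36 log units; beyond the scatter); the gap from compound 1 to compound 3 is the widest in the set.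

Compound 4 `Cc1cc(S(=O)(=O)/N=C(\N)N/N=C/C#Cc2ccccc2)c(SCc2ccc(C(F)(F)F)cc2)cc1Cl` differs from compound 1 by trifluoromethyl in place of hydrogen on an aromatic carbon. Among the measured compounds shown here, the one measured step that speaks to this change is the one from compound 2 to compound 3, where the same trifluoromethyl-for-hydrogen exchange on the benzylsulfanyl ring, on a different aromatic carbon, gave a 2.3-fold higher number from compound 2 to compound 3 (0.36 log units; beyond the scatter). Nothing in the data shows how the exchange behaves at the position para to a large group, so the expectation rests on that single step and carries its uncertainty.

For the measured compounds named here, compound 4 is therefore expected to show a modestly higher number than compound 1, a step in the same direction as the one seen between compound 2 and compound 3, amounting to a 2.0-fold higher number from compound 1 to compound 4 (0.30 log units; within the scatter). Compound 4 is estimated at 16000 nM in this assay, with a range from 7000 nM to 36000 nM.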

Compound 4, half-maximal inhibitory concentration: 70000 nM
Estimate against measurement, compound 4: 4.4-fold (0.64 log units) below, outside the stated range (above it).
By their numbers in this assay, from the lowest: compounds 1 and 2 (each within the scatter of the next); then compound 3; then compound 4.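

In this assay, trifluoromethyl in place of hydrogen on an aromatic carbon, para to a large group, gives an 8.8-fold higher number from compound 1 to compound 4 (0.94 log units; beyond the scatter), so this place on the benzylsulfanyl ring of the core of compound 1 tolerates the exchange poorly. The earlier compounds shown here showed only a modest rise for this exchange, and the new step shows that it has no single size across these compounds: the same change on two cores in this assay, a 2.3-fold higher number (0.36 log units; beyond the scatter) from compound 2 to compound 3 and an 8.8-fold higher number (0.94 log units; beyond the scatter) from compound 1 to compound 4, 3.8-fold (0.58 log units) apart, beyond the scatter of two such steps. Both steps still run in the same direction, towards a higher number, and neither of the two goes against that direction, although two steps are a narrow base for any wider pattern.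

The two steps differ both in the aromatic carbon that carries the trifluoromethyl and in the core, so the compounds shown leave open whether the larger step follows the place on the ring, the core or the two together. They also leave open whether the rise belongs to trifluoromethyl itself or would also appear with another group at this place, such as fluorine, a methoxy group, an amine or a carboxylic acid.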